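The compounds below may be only part of what the source reports. "The series", "measured", "known", "first", "only" and "open" are said of these compounds alone.

Measured compounds:
- Compound 1 `Nc1cc(N)c2nc(-c3ccccc3)c(NCc3ccc(Cl)c(Cl)c3)nc2c1` gives 43700 nM in a functional assay on UACC-257 cells (Homo sapiens) for inhibition, read by sulforhodamine B assay, with a stated time of 48 h; on this read-out lower numbers stand for higher toxicity in this test and higher numbers for lower toxicity in this test.
- Compound 2 `Nc1cc(N)c2nc(-c3ccccc3)c(Sc3ccc(F)cc3)nc2c1` gives 60300 nM in this assay.
- Compound 3 `CCOC(=O)[C@H](CCC(=O)O)NC(=O)c1ccc(Oc2nc3cc(N)cc(N)c3nc2-c2ccccc2)cc1` is reported in this assay only as a limit, < 100000 nM, not as a number.

All three compounds share the same core and were tested in this assay, which reads the concentration lethal to the cells. Compound 1 has the lowest of the two numbers given, but compound 2 sits close to it, and that gap is within the usual scatter of such measurements, so no difference between the two can be claimed. For compound 3 only a limit is known: the limit of < 100000 nM in this assay, at which 1 of the 3 values shown sits.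

Compound 4 `COc1ccc(CNc2nc3cc(N)cc(N)c3nc2-c2ccccc2)cc1` has not yet been measured. It differs from compound 1 in one place: 4-methoxyphenyl in place of 3,4-dichlorophenyl on a saturated chain carbon bound to a nitrogen on an aromatic ring. Among the compounds with values here, no measured pair in this set shows the effect of such a swap, so the expectation rests on compound 1 alone. The numbers seen so far all lie in the same weak range, and a change at the outer end of the benzyl chain is expected to move the value only modestly. The step of a 1.3-fold higher number from compound 1 to compound 4 (0.10 log units; within the scatter) is therefore estimated to stay near the scatter, with compound 4 expected to give about 55000 nM, somewhere between 20000 nM and 150000 nM.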

Compound 4, concentration lethal to 50% of the cells: 56200 nM
For compound 4 the middle estimate is 1.0-fold (0.01 log units) below the measured one, and the stated range covers the measured number.
By their numbers in this assay, from the lowest: compounds 1, 4 and 2 (each within the scatter of the next).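

In this assay, within the data shown here, this is the first comparison in the set between two compounds that differ in only one place: moving from 3,4-dichlorobenzyl to 4-methoxybenzyl gives a 1.3-fold higher number from compound 1 to compound 4 (0.11 log units; within the scatter), so no difference between the two can be claimed. The exchange is not a small one on paper, since a ring carrying 2 chlorine atoms and no hydrogen-bond acceptor gives way to a ring carrying an oxygen and 1 hydrogen-bond acceptor, with the same count of heavy atoms, yet the read-out does not separate the two compounds. The measurements shown offer no explanation for this outcome.

Going by these compounds, only these two ring groups have been compared at this position, so it remains open whether a carboxylic acid or an amine on the ring, or a longer chain linking the ring to the nitrogen, would move the number beyond the scatter. Also open, on these data alone, is whether a single chlorine would behave like the 3,4-dichlorophenyl group, as this one pair cannot show how each substituent contributes on its own.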